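Changing the Amide Group on Compound 3

The source may hold more compounds than are shown below. What is called first, only, known or untested is meant among the compounds shown, and "the series" means these compounds.

Measured in a functional assay on PC-3 cells (Homo sapiens) for antiproliferative activity, read by MTT assay, with a stated time of 48 h; a lower number here means a stronger inhibitor, a higher number a weaker inhibitor:
- Compound 1 `CCN(CC)CCNC(=O)c1ccc(C(CC)(CC)c2ccc(OCCC(O)(CC)CC)c(C)c2)n1CC`: 3350 nM.
- Compound 2 `CCOc1ccc(NC(=O)c2ccc(C(CC)(CC)c3ccc(OCCC(O)(CC)CC)c(C)c3)n2CC)cc1`: > 50000 nM, a limit of the assay and not a number.
- Compound 3 `CCn1c(C(=O)NC(C)C(=O)O)ccc1C(CC)(CC)c1ccc(OCCC(O)(CC)CC)c(C)c1`: 11700 nM.

Of the two results that are true numbers, compound 3 holds the higher, so it is the weaker inhibitor of that pair. The step linking them is a 3.5-fold higher number from compound 1 to compound 3 (0.54 log units; beyond the scatter).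

Compound 4 `CCn1c(C(=O)NC(CO)CCO)ccc1C(CC)(CC)c1ccc(OCCC(O)(CC)CC)c(C)c1` has not yet been measured. It carries 3-hydroxy-1-(hydroxymethyl)propyl in place of 1-carboxyethyl on an amide-type nitrogen.

All three measured steps change the group at this same place, so they are the relevant guide. The largest is an at least 14-fold higher number from compound 1 to compound 2 (1.17 log units; beyond the scatter), and another is an at least 4.2-fold lower number from compound 2 to compound 3 (0.63 log units; beyond the scatter). Thus, this place can matter a great deal, but none of these steps involves the incoming group. Both groups in the present step lack a ring, as in the modest step between compound 1 and compound 3, whereas the large steps involve the 4-ethoxyphenyl of compound 2. A small step is therefore expected in this assay, probably within the scatter and with no firm direction.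

The expected change is a 1.1-fold higher number from compound 3 to compound 4 (0.05 log units; within the scatter). For compound 4, the estimated value is 13000 nM, with an expected range of 5000 nM to 35000 nM.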

Compound 4, half-maximal inhibitory concentration: 8760 nM
Beside the measured number, compound 4's estimate is 1.5-fold (0.17 log units) above it; measured number inside the range.
By their numbers in this assay, from the lowest: compound 1; then compounds 4 and 3 (each within the scatter of the next). At a limit, above all of these: compound 2.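

In this assay, putting 3-hydroxy-1-(hydroxymethyl)propyl in place of 1-carboxyethyl on the amide-type nitrogen gives a 1.3-fold lower number from compound 3 to compound 4 (0.13 log units; within the scatter), so these two ring-free groups cannot be told apart at this position. The new group also stays apart from 2-(diethylamino)ethyl, with a 2.6-fold higher number from compound 1 to compound 4 (0.42 log units; beyond the scatter), which leaves compound 1 with the lowest number of the four, and the second ring-free group now shows that the gap seen with compound 3 is not confined to 1-carboxyethyl. Against 4-ethoxyphenyl the change gives an at least 5.7-fold lower number from compound 2 to compound 4 (0.75 log units; beyond the scatter), but this step has no exact size, as compound 2 stands at a limit of the assay and not a number: the limit of > 50000 nM in this assay, at which 1 of the 4 values shown sits.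

Compound 1 is the only one shown with an amine, so a single example cannot tell whether the amine itself or the length of its chain goes with the lower number. Also open, as far as these compounds go, is whether a shorter dimethylaminoethyl group, a longer aminobutyl chain or a simple 2-hydroxyethyl group would follow compound 1 or stay with compound 3 and compound 4.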